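Replacing tert-butoxycarbonyl with trifluoromethyl: compound 3 to compound 4

The compounds below may be only part of what the source reports. "The series", "measured", "known", "first", "only" and "open" are said of these compounds alone.

Of the compounds shown here, three have been tested in a functional assay on MKN-45 cells (Homo sapiens) for antiproliferative activity, tested at 1 uM; a lower number here means less inhibition, a higher number more inhibition at the concentration tested (going by the name of the read-out). Compound 1 `Cc1nn(-c2ccccc2)c(Oc2ccc(Cl)cc2)c1/C=N/OCc1ccc(C(=O)OC(C)(C)C)cc1` gives -9.9%, compound 2 `Cc1ccc(CO/N=C/c2c(C)nn(C)c2Oc2ccc(Cl)cc2)cc1` gives 30.4%, and compound 3 `CC(C)c1nn(-c2ccccc2)c(Oc2ccc(Cl)cc2)c1/C=N/OCc1ccc(C(=O)OC(C)(C)C)cc1` gives -27%. Compound 3 thus stands lowest of the three, with compound 1 its nearest neighbour and compound 2 the furthest, both gaps beyond the scatter. Among the measured compounds shown here, the only single-point step among the measured compounds is a number 17.1 percentage points lower from compound 1 to compound 3 (beyond the scatter), which concerns the group on the shared core rather than the ester end of the molecule.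

Compound 4 `CC(C)c1nn(-c2ccccc2)c(Oc2ccc(Cl)cc2)c1/C=N/OCc1ccc(C(F)(F)F)cc1` differs from compound 3 in one place: trifluoromethyl in place of tert-butoxycarbonyl on an aromatic carbon. For the measured compounds named here, no measured step covers this particular change, and compound 2 differs from compound 3 in several places at once, so its value cannot be read as a guide. Going by the values given here, with no direct precedent, the expected change is a number 12 percentage points higher from compound 3 to compound 4 (beyond the scatter), within the scatter. Compound 4 is therefore estimated at -15%, with a range from -45% to 20%.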

Compound 4, a percentage reported as inhibition, at one concentration (the size of the read-out at that concentration, not a potency): -15.4%
Compound 4: the middle estimate sits 0.4 percentage points above what was measured, and the stated range covers the measured number.
By their numbers in this assay, from the lowest: compound 3; then compounds 4 and 1 (each within the scatter of the next); then compound 2.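

Swapping the group para to a large group on the six-membered aromatic ring gives a number 11.6 percentage points higher from compound 3 to compound 4 (beyond the scatter) in this assay, so this end of the molecule also affects the read-out, whereas the only earlier step concerned a group on the shared core. The change does not bring a positive number, though: compound 3 gives -27% and compound 4 gives -15.4%, so trifluoromethyl in place of tert-butoxycarbonyl, with hydrogen-bond acceptors lost in the exchange, yields no measurable inhibition at the concentration tested. Nothing available explains why this step occurs.

Still open, from the compounds shown here alone, is how a carboxylic acid or an amine would read at this same place. It is also unknown whether the step would hold on the core of compound 1, which carries methyl in place of isopropyl.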